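The source may hold more compounds than are shown below. What is called first, only, known or untested is meant among the compounds shown, and "the series" means these compounds.

Measured in a functional assay on HepG2 cells (Homo sapiens) for antiproliferative activity, read by MTT assay, with a stated time of 72 h; a higher number here means a weaker inhibitor, a lower number a stronger inhibitor:
Compound 1 `COc1cc2c(Nc3ccc(C#N)cc3)ncnc2cc1OCCCN(C)C`: > 100000 nM (a limit of the assay)
Compound 2 `COc1cc2c(Nc3ccc(C#N)cc3)ncnc2cc1OCCCN1CCN(C)CC1`: 13800 nM

Only one of these two results is an actual number. In this assay, compound 2 gives 13800 nM, and nothing else yet stands beside it as a number. Compound 1 gives > 100000 nM, which is a limit of the assay.

The next compound, compound 3 `COc1cc2c(Nc3cccc(C#N)c3)ncnc2cc1OCCCN1CCN(C)CC1`, has the same atoms as compound 2, joined differently: it carries 3-cyanophenyl in place of 4-cyanophenyl on a nitrogen on an aromatic ring.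

One measured step exists, an at least 7.2-fold lower number from compound 1 to compound 2 (0.86 log units; beyond the scatter). It is beyond the scatter, but it put 4-methylpiperazin-1-yl in place of dimethylamino on the chain and left the 4-cyanophenyl untouched. Going by the values given here, it therefore says nothing direct about moving the nitrile, and no measured step covers that change. With no evidence for a direction, no shift beyond the scatter is expected, though the uncertainty is wide.

The expected step is a 1.4-fold lower number from compound 2 to compound 3 (0.14 log units; within the scatter).

For compound 3, the estimated value is 10000 nM, with an expected range of 3500 nM to 30000 nM.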

Compound 3, half-maximal inhibitory concentration: 18300 nM
Beside the measured number, compound 3's estimate is 1.8-fold (0.26 log units) below it, within the range that was stated.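

In this assay, replacing 4-cyanophenyl with 3-cyanophenyl on a nitrogen on an aromatic ring gives a 1.3-fold higher number from compound 2 to compound 3 (0.12 log units; within the scatter), so the two placements of the nitrile cannot be told apart on these numbers. Going by these compounds alone, the one earlier step concerned only the chain, so this is the first measured reading at the aromatic group on that nitrogen, and with 4-methylpiperazin-1-yl on the chain it shows no separation between these two cyanophenyl groups. Compound 1 still stands only as a limit of the assay, which leaves this as the one step with an actual number at both ends: the limit of > 100000 nM in this assay, at which 1 of the 3 values shown sits.

What the compounds leave open is whether the same holds with dimethylamino on the chain, as 3-cyanophenyl appears here only together with 4-methylpiperazin-1-yl. Also open, from the compounds shown here alone, is how this assay result would respond to a different group on that phenyl ring, such as a chlorine, a methoxy group or a carboxylic acid in place of the nitrile, or to a morpholine ring or a longer chain at the end of the side chain.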